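Compound 3 to compound 4: replacing the pentafluorophenyl group

The source may report more compounds than this note shows. Statements on the series, on what has been measured and on what is new or still open speak of the compounds shown alone.

In a functional assay on DU-145 cells (Homo sapiens) for inhibition, read by trypan blue exclusion, with a stated time of 96 h (a higher number here means a weaker inhibitor of growth, a lower number a stronger inhibitor of growth), compound 3 `O=C(/C(=C\c1ccc([N+](=O)[O-])c(O)c1)SCc1ccc(Br)cc1)c1c(F)c(F)c(F)c(F)c1F` gives 10000 nM and compound 1 `O=C(O)c1ccc(C(=O)/C(=C\c2ccc([N+](=O)[O-])c(O)c2)SCc2ccc(Br)cc2)cc1` gives 10000 nM so the two stand level at the digits shown. For compound 2 `O=C(/C(=C\c1ccc([N+](=O)[O-])c(O)c1)SCc1ccc(Br)cc1)C1CCNC1` the figure of > 100000 nM is a limit and not a number.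

Compound 4 `O=C(/C(=C\c1ccc([N+](=O)[O-])c(O)c1)SCc1ccc(Br)cc1)c1cc(Cl)ccc1O` keeps the core of compound 3 and differs in one place: 5-chloro-2-hydroxyphenyl in place of 2,3,4,5,6-pentafluorophenyl on a carbonyl carbon with 5-chloro-2-hydroxyphenyl in place of 2,3,4,5,6-pentafluorophenyl on a carbonyl carbon.

Three measured steps fall at this same place. Within the data shown here, the exchange of one substituted phenyl group for another gave no change at the digits printed from compound 1 to compound 3 (within the scatter) and is the closest precedent. Pyrrolidin-3-yl in place of 4-carboxyphenyl gave an at least 10-fold higher number from compound 1 to compound 2 (1.00 log units; beyond the scatter) and 2,3,4,5,6-pentafluorophenyl in place of pyrrolidin-3-yl gave an at least 10-fold lower number from compound 2 to compound 3 (1.00 log units; beyond the scatter) but both of these rest on the limit for compound 2 and neither exchanges one phenyl group for another. Compound 4 retains a phenyl group at this place, so the step with no change between compound 1 and compound 3 is taken as the guide.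

In this assay the expected step is a 1.3-fold lower number from compound 3 to compound 4 (0.10 log units; within the scatter) with no move beyond the scatter anticipated. The estimate for compound 4 is 8000 nM and the expected range runs from 2500 nM to 30000 nM on only these few values.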

Compound 4, concentration for 50% growth inhibition: 10000 nM
Compound 4: middle estimate off by 1.3-fold (0.10 log units), on the low side; low and high end bracket the measured number.
By their numbers in this assay, from the lowest: compounds 1, 3 and 4 (each within the scatter of the next). At a limit, above all of these: compound 2.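

In this assay, a third phenyl group on the carbonyl carbon gives no change at the digits printed from compound 3 to compound 4 (within the scatter) and no change at the digits printed from compound 1 to compound 4 (within the scatter), so 5-chloro-2-hydroxyphenyl, with the hydrogen-bond donor and acceptor counted on it, cannot be told apart from 2,3,4,5,6-pentafluorophenyl, which has neither, or from 4-carboxyphenyl. The only separation at this place remains the one involving pyrrolidin-3-yl, now seen with a further phenyl group as an at least 10-fold lower number from compound 2 to compound 4 (1.00 log units; beyond the scatter). For compound 2 the value is a limit and not a number: the limit of > 100000 nM in this assay, at which 1 of the 4 values shown sits.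

Open, as far as these compounds go, is whether an unsubstituted phenyl group, a phenyl group carrying an amine, or a longer alkyl chain on the carbonyl carbon would stand with compounds 1, 3 and 4 or with compound 2. Equally open, from the compounds shown here alone, is whether a cyclohexyl group, which has no amine, would go with pyrrolidin-3-yl or with the phenyl groups.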